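The source may hold more compounds than are shown below. What is called first, only, known or untested is meant among the compounds shown, and "the series" means these compounds.

Compound 2 `Fc1ccccc1Cn1nnc2c(NC3CC3)nc(-c3ccccc3)nc21` is the weaker of the two binders measured so far in an assay on isolated protein for binding affinity to adenosine receptor A1 (Bos taurus); a lower number here means a stronger inhibitor, a higher number a weaker inhibitor: compound 2 gives 15000000 nM, whereas compound 1 `Fc1ccccc1Cn1nnc2c(NC3CCCCC3)nc(-c3ccccc3)nc21` gives 1150000 nM. For the measured compounds named here, the only measured step, a 13-fold higher number from compound 1 to compound 2 (1.12 log units; beyond the scatter), shows how strongly the group on the ring nitrogen matters in this assay. Compound 3 `CC(O)CNc1nc(-c2ccccc2)nc2c1nnn2Cc1ccccc1F` carries the change (2-hydroxypropyl in place of cyclopropyl on a nitrogen on an aromatic ring). The measured step bears on it only loosely: it replaced one carbon ring by a smaller one, while here a ring gives way to a chain that is one heavy atom longer and brings a hydroxyl. Because the smaller group gave the higher number in a 13-fold higher number from compound 1 to compound 2 (1.12 log units; beyond the scatter), a somewhat bulkier chain is expected to bring the number down a little, but the hydroxyl has no precedent among these compounds, so only a small step is expected for a 1.9-fold lower number from compound 2 to compound 3 (0.27 log units; within the scatter). Compound 3 is therefore expected to give about 8000000 nM in this assay, within a range of 1500000 nM to 40000000 nM.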

Compound 3, inhibition constant: 4800000 nM
Estimate against measurement, compound 3: 1.7-fold (0.22 log units) above; the measured number falls inside the stated range.
By their numbers in this assay, from the lowest: compound 1; then compound 3; then compound 2.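

In this assay, a lower number at this nitrogen does not require a carbon ring: a 3.1-fold lower number from compound 2 to compound 3 (0.49 log units; beyond the scatter) shows that the open 2-hydroxypropyl chain, with its hydrogen-bond donor and acceptor, gives a lower number than cyclopropyl. Cyclohexyl still gives a lower number than this chain, with a 4.2-fold higher number from compound 1 to compound 3 (0.62 log units; beyond the scatter), so compound 3 falls between the two ring-bearing compounds and ring size alone does not set the order among the three. No supporting evidence bears on what lies behind these steps.

The compounds shown leave open whether the hydroxyl contributes to the step at all, since a plain propyl chain could give a similar number to 2-hydroxypropyl. They also leave open how a longer chain ending in an amine, or a phenyl ring, would compare with cyclohexyl at this nitrogen.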